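The source may report more compounds than this note shows. Statements on the series, on what has been measured and on what is new or still open speak of the compounds shown alone.

Compound 1 `O=C(NNc1ccccc1F)c1ccccc1NS(=O)(=O)c1cnc(O)nc1O`: > 20000 nM (a limit of the assay)
Compound 2 `Cc1ccc(C(=O)NNC(=O)c2ccccc2NS(=O)(=O)c2cnc(O)nc2O)cc1`: > 20000 nM (a limit of the assay)

In a functional assay on MDA-MB-231 cells (Homo sapiens) for antiproliferative activity, read by MTT assay, with a stated time of 24 h (a lower number here means a stronger inhibitor, a higher number a weaker inhibitor), compound 2 gives no number, only the limit > 20000 nM. Compound 1 also gives only a limit, > 20000 nM. All that is known so far is the limit of > 20000 nM in this assay, at which 2 of the 2 values shown sit.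

Compound 3 `O=C(NNC(=O)c1ccccc1NS(=O)(=O)c1cnc(O)nc1O)c1cccc(Cl)c1` keeps the rest of compound 2 and changes one group: 3-chlorophenyl in place of 4-methylphenyl on a carbonyl carbon. The 3-chlorophenyl stands in place of 4-methylphenyl on a carbonyl carbon. Among the compounds with values here, the only measured step is a step that the two limits leave unreadable from compound 1 to compound 2, so it offers no size to carry over to this change. With no readable step to go on, no shift beyond the scatter is expected in either direction, and another limit in this assay is the likeliest outcome. The expected change is a step that the limit leaves unreadable from compound 2 to compound 3. Compound 3 is estimated at 25000 nM, with an expected range from 8000 nM to 60000 nM.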

Compound 3, half-maximal inhibitory concentration: 4420 nM
Beside the measured number, compound 3's estimate is 5.7-fold (0.75 log units) above it; measured number outside the range, below it.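

In this assay, 3-chlorophenyl in place of 4-methylphenyl on a carbonyl carbon gives an at least 4.5-fold lower number from compound 2 to compound 3 (0.65 log units; beyond the scatter), which shows that this position responds to a change of group even though both groups count the same heavy atoms. Against the earlier compound with 2-fluorophenyl on an amine nitrogen, (3-chlorophenyl)carbonyl gives an at least 4.5-fold lower number from compound 1 to compound 3 (0.65 log units; beyond the scatter). The step between the two earlier compounds cannot be read, so compound 3 is the first to give a number rather than a limit of the assay: the limit of > 20000 nM in this assay, at which 2 of the 3 values shown sit.

The true size of both new steps stays open, and the compounds shown do not separate the effect of adding chlorine from that of removing the methyl group. Going by these compounds, whether a bromophenyl, a methoxyphenyl or an aminophenyl group would match this result also remains open.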